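Aryl substituent changes on the triazole series

This account rests on a few compounds, and the source may have more. Where it says the series, first, only, none or still open, it means among the compounds named here.

Compound 2 `Cc1ccc(-c2cn(C[C@H]3c4c(ccc(OS(=O)(=O)c5ccc(C)cc5)c4C)[C@@H]4CC[C@@]5(C)C[C@]43CC5=O)nn2)cc1` sits at a limit in a functional assay on A549 cells (Homo sapiens) for cytotoxicity, read by MTT assay, with a stated time of 4 days (a lower number here means a stronger inhibitor, a higher number a weaker inhibitor), giving > 20000 nM. Compound 1 `Cc1ccc(S(=O)(=O)Oc2ccc3c(c2C)[C@H](Cn2cc(-c4ccc(Br)cc4)nn2)[C@@]24CC(=O)[C@@](C)(CC[C@@H]32)C4)cc1` likewise stands at a limit in this assay with > 20000 nM. The step that the two limits leave unreadable from compound 1 to compound 2 cannot be read, since both values sit at the limit of > 20000 nM in this assay, at which 2 of the 2 values shown sit. Compound 3 `Cc1ccc(S(=O)(=O)Oc2ccc3c(c2C)[C@H](Cn2cc(-c4ccc(F)cc4)nn2)[C@@]24CC(=O)[C@@](C)(CC[C@@H]32)C4)cc1` differs from compound 2 by fluoro in place of methyl on an aromatic carbon, para to a large group. Among the compounds with values here, the only related measured step is unreadable, so no size can be drawn from it. Compound 3 is therefore expected to remain at the limit, with an estimate of 25000 nM spanning 10000 nM to 60000 nM. The expected step that the limit leaves unreadable from compound 2 to compound 3 is none beyond the scatter.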

Compound 3, half-maximal inhibitory concentration: > 20000 nM
Compound 3: a limit, no number; the forecaster's own chance of this, stated with the estimate: 85%; the middle value is on the limit's open side.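

No new step can be read among compound 1, compound 2 and compound 3, since all three stand at a limit: the limit of > 20000 nM in this assay, at which 3 of the 3 values shown sit.

The compounds shown leave open whether any aryl substituent on the triazole gives a readable value.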